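The compounds below may be only part of what the source reports. "The series", "measured", "known", "first", "only" and "open" are said of these compounds alone.

Measured compounds:
compound 1 `CCCNc1ccc(NC(=O)c2cc(Cl)ccc2O)c(Cl)c1` — 22500 nM
compound 2 `CC(C)CNc1ccc(NC(=O)c2cc(Cl)ccc2O)c(Cl)c1` — 60000 nM

In an ADME assay on A549 cells (Homo sapiens) for cytotoxicity, read by resazurin assay, with a stated time of 48 h (on this read-out higher numbers stand for lower toxicity in this test and lower numbers for higher toxicity in this test), compound 1 gives 22500 nM, the lowest of the two numbers shown, with compound 2 giving 60000 nM. Among the measured compounds shown here, the one measured step, a 2.7-fold higher number from compound 1 to compound 2 (0.43 log units; beyond the scatter), saw a larger alkyl group on the nitrogen on an aromatic ring. Compound 3 `O=C(Nc1ccc(NC2CCCCC2)cc1Cl)c1cc(Cl)ccc1O` carries the change (cyclohexyl in place of propyl on a nitrogen on an aromatic ring), again a larger alkyl group at that nitrogen. By analogy, a modest upward step in this assay is expected, though no cyclic group has been measured here. Compound 3 is estimated at 45000 nM, within 20000 nM to 100000 nM, which means an expected step of a 2.0-fold higher number from compound 1 to compound 3 (0.30 log units; within the scatter).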

Compound 3, half-maximal cytotoxic concentration: 68300 nM
For compound 3 the middle estimate is 1.5-fold (0.18 log units) below the measured one; measured number inside the range.
By their numbers in this assay, from the lowest: compound 1; then compounds 2 and 3 (each within the scatter of the next).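

In this assay, a ring on this nitrogen shows the same direction as the isobutyl chain: cyclohexyl in place of propyl gives (a 3.0-fold higher number from compound 1 to compound 3 (0.48 log units; beyond the scatter)). Cyclohexyl in place of isobutyl gives (a 1.1-fold higher number from compound 2 to compound 3 (0.06 log units; within the scatter)), so the cyclic and branched groups cannot be told apart at this position. Nothing available explains either step. Still open, as far as these compounds go, is whether a smaller ring such as cyclopropyl, or an aromatic phenyl group, would fit the same picture. From the compounds shown here alone, how a chain carrying an amine or a carboxylic acid would read at this nitrogen also remains open.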